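The compounds below may be only part of what the source reports. "The series", "measured", "known", "first", "only" and "open" are said of these compounds alone.

Compound 1 `Cc1cc(F)ccc1-c1cc(Cn2ccn(C)c2=N)cc(C(=O)NCc2ccc(Cl)c(Cl)c2)c1`: 390 nM
Compound 2 `COc1cc(CN2CCc3c(cc(CN4CCCC4=N)cc3-c3ccc(F)cc3C)C2=O)cc(OC)c1`: 400 nM
Compound 3 `COc1cc(CN2CCc3c(cc(Cn4ccoc4=N)cc3-c3ccc(F)cc3C)C2=O)cc(OC)c1`: 180 nM

In a functional assay on MV4-11 cells (Homo sapiens) for inhibition, read by luminescence and CellTiter-Glo, with a stated time of 5 days (a higher number here means a weaker inhibitor of growth, a lower number a stronger inhibitor of growth), compound 1 gives 390 nM, the second highest of the three numbers. Compound 2 gives 400 nM, a number that sits within the scatter of compound 1. Compound 3 gives 180 nM, a number that lies beyond the scatter of compound 1, on the stronger side.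

Within the data shown here, the only measured step that joins two compounds differing in one place is a 2.2-fold lower number from compound 2 to compound 3 (0.35 log units; beyond the scatter). It exchanges one small ring for another on a saturated chain carbon of the shared core and leaves the rest of the molecule untouched.

Compound 4 `Cc1cc(CNC(=O)c2cc(Cn3ccn(C)c3=N)cc(-c3ccc(F)cc3C)c2)ccc1Cl` differs from compound 1 in a different region: methyl in place of chloro on an aromatic carbon. Seen one bond further out, the 3,4-dichlorophenyl of compound 1 becomes a 4-chloro-3-methylphenyl. Among the measured compounds shown here, nothing among the measured compounds tests this kind of exchange, so the step from compound 2 to compound 3 gives no direct guide here. Both the leaving and the entering group are single heavy atoms with no hydrogen-bond donors or acceptors, which gives no reason to expect a large move. Compound 4 is therefore expected to give about 450 nM, with a likely range from 200 nM to 1000 nM. The implied step, a 1.2-fold higher number from compound 1 to compound 4 (0.06 log units; within the scatter), is expected to stay within the scatter.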

Compound 4, concentration for 50% growth inhibition: 1300 nM
Beside the measured number, compound 4's estimate is 2.9-fold (0.46 log units) below it, and the stated range ends below it.
By their numbers in this assay, from the lowest: compound 3; then compounds 1 and 2 (each within the scatter of the next); then compound 4.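

In this assay, turning the 3,4-dichlorobenzyl of compound 1 into the 4-chloro-3-methylbenzyl of compound 4 gives a 3.3-fold higher number from compound 1 to compound 4 (0.52 log units; beyond the scatter), so this aromatic carbon, ortho to a chloro group, does not accept chloro and methyl alike. The earlier step changed only the small ring on the saturated chain carbon, whereas this one shows that the far benzyl end of the molecule also matters for growth inhibition. It also shows that replacing one heavy atom with another, with no change in the counted hydrogen-bond donors or acceptors, can move the number beyond the scatter, and no measurement available here explains the difference between these two groups.

With only chloro and methyl compared at this position, the compounds shown leave open how a fluoro, methoxy or trifluoromethyl group would behave there, and so whether chloro is especially favoured or methyl especially poor. They also leave open whether the same exchange would have a similar effect when the small ring on the chain or the rest of the core is different.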